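Methoxy Groups Entering at the Saturated Ring Carbon

The source may hold more compounds than are shown below. What is called first, only, known or untested is meant among the compounds shown, and "the series" means these compounds.

Of the compounds shown here, three sharing one core have been measured in a functional assay on the whole organism (strain Wistar) for inhibition, with Rattus norvegicus as the target, read by paw edema, with stated times of 30 min and 3 h, at a dose of 20 mg/kg by the oral route; a higher number here means more inhibition at the dose given (going by the name of the read-out), a lower number less inhibition. Compound 1 `Cc1cc(O)c(C2=NN(c3ccc(S(N)(=O)=O)cc3)C(c3ccccc3)C2)cc1Cl` gives 47.4%, compound 2 `COc1ccc(C2CC(c3cc(Cl)c(C)cc3O)=NN2c2ccc(S(N)(=O)=O)cc2)c(OC)c1OC` gives 68.4%, and compound 3 `COc1cc(C)c(Cl)cc1C1=NN(c2ccc(S(N)(=O)=O)cc2)C(c2cccc(O)c2)C1` gives 39.5%, the lowest of the three; its gap to compound 1 lies within the scatter, its gap to compound 2 beyond it. Compound 4 `COc1ccc(C2CC(c3cc(Cl)c(C)cc3OC)=NN2c2ccc(S(N)(=O)=O)cc2)cc1OC` differs from compound 3 in one place: 3,4-dimethoxyphenyl in place of 3-hydroxyphenyl on a saturated ring carbon. Going by the values given here, the single measured step that bears on this, a number 21 percentage points higher from compound 1 to compound 2 (beyond the scatter), likewise placed a methoxy-bearing phenyl on a saturated ring carbon and raised inhibition modestly. A rise of similar size is therefore expected for compound 4, namely a number 15.5 percentage points higher from compound 3 to compound 4 (beyond the scatter). Compound 4 is thus estimated at 55%, with a range from 40% to 70%.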

Compound 4, a percentage reported as inhibition, in the whole organism at one dose (the size of the read-out at that dose, not a potency): 31.6%
Estimate against measurement, compound 4: 23.4 percentage points above; measured number outside the range, below it.
By their numbers in this assay, from the lowest: compounds 4, 3 and 1 (each within the scatter of the next, the first and the last beyond it); then compound 2.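

On this saturated ring carbon, a phenyl bearing methoxy groups does not bring more inhibition by itself in this assay: 3,4-dimethoxyphenyl in place of 3-hydroxyphenyl gives (a number 7.9 percentage points lower from compound 3 to compound 4 (within the scatter)). The rise with 2,3,4-trimethoxyphenyl (a number 21 percentage points higher from compound 1 to compound 2 (beyond the scatter)) therefore does not extend to every such phenyl, although the two steps start from different groups. Nothing measured here explains the contrast.

On these data alone, whether the number of methoxy groups or their ring positions matter remains open. So does the outcome with a phenyl carrying an amine or a carboxylic acid on this carbon.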